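Hydroquinone to Quinone on a Pyrazole Core: Growth Inhibition

This account rests on a few compounds, and the source may have more. Where it says the series, first, only, none or still open, it means among the compounds named here.

Of the compounds shown here, two have been measured. Compound 1 `Oc1ccc(O)c(-c2cc(-c3ccc(Cl)cc3)nn2-c2ccccc2)c1` is the reference; in a functional assay on cells (Melanoma cell, Homo sapiens) for cytotoxicity, read by sulforhodamine B assay, with a stated time of 48 h (on this read-out lower numbers stand for stronger inhibition of growth and higher numbers for weaker inhibition of growth), compound 1 gives 8790 nM, the lowest of the two numbers recorded. Compound 2 `NS(=O)(=O)c1ccc(-n2nc(-c3ccc(Cl)cc3)cc2-c2cc(O)ccc2O)cc1` carries a sulfamoyl group on the phenyl ring and in this assay gives 14600 nM; the step is a 1.7-fold higher number from compound 1 to compound 2 (0.22 log units; within the scatter), so the two compounds sit within the scatter of each other.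

The third compound, compound 3 `O=C1C=CC(=O)C(c2cc(-c3ccc(Cl)cc3)nn2-c2ccccc2)=C1`, has not yet been measured in this assay. It differs from compound 1 in one place: a group of 8 heavy atoms (6 carbon, 2 oxygen; one six-membered non-aromatic ring of carbon only) in place of a group of 8 heavy atoms (6 carbon, 2 oxygen; one six-membered aromatic ring of carbon only), on an aromatic carbon.

Going by the values given here, no measured step bears on this change. Among the compounds with values here, the only step recorded, a 1.7-fold higher number from compound 1 to compound 2 (0.22 log units; within the scatter), touches the phenyl ring and not the dihydroxyphenyl group, and it lay within the scatter. The data therefore give no direction for the move from the aromatic ring to the non-aromatic ring with its four double bonds, and a step of any size beyond the scatter cannot be grounded on them. Compound 3 is therefore expected to give about 6000 nM in this assay, with a range from 1500 nM to 25000 nM, which means an expected step of a 1.5-fold lower number from compound 1 to compound 3 (0.17 log units; within the scatter).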

Compound 3, concentration for 50% growth inhibition: 69400 nM
Compound 3: middle estimate off by 12-fold (1.06 log units), on the low side, and the stated range ends below it.
By their numbers in this assay, from the lowest: compounds 1 and 2 (each within the scatter of the next); then compound 3.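

At the aromatic carbon next to the ring nitrogen, replacing the 2,5-dihydroxyphenyl group with the six-membered non-aromatic ring of carbon only gives, in this assay, a 7.9-fold higher number from compound 1 to compound 3 (0.90 log units; beyond the scatter), so growth inhibition here is weaker and the change at this position registers clearly. The other change shown, sulfamoyl on the phenyl ring, gives a 1.7-fold higher number from compound 1 to compound 2 (0.22 log units; within the scatter), so of the two places altered from compound 1, only the change at the 2,5-dihydroxyphenyl group moves the number beyond the scatter. Nothing in the data shown accounts for this loss of growth inhibition.

The compounds shown do not separate the change from an aromatic to a non-aromatic ring from the change from 2 hydrogen-bond donors to 0, and a compound with methoxy groups in place of the hydroxyl groups on the aromatic ring would bear on that question. They also leave open how the non-aromatic ring would read alongside sulfamoyl on the phenyl ring, and whether an amine or a carboxylic acid at this position of the shared core would keep the growth inhibition of compound 1.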